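Ester variation on a shikonin-type core: three measured, one awaited

This account rests on a few compounds, and the source may have more. Where it says the series, first, only, none or still open, it means among the compounds named here.

Compound 3 `CC[C@](C)(O)CC(=O)O[C@H](CC=C(C)C)C1=CC(=O)c2c(O)ccc(O)c2C1=O` gives 20500 nM in a functional assay on DU-145 cells (Homo sapiens) for cytotoxicity, read by MTT assay (a higher number here means a weaker inhibitor, a lower number a stronger inhibitor), the lowest of the three numbers recorded so far. Its nearest neighbour is compound 1 `CC(C)=CC[C@@H](OC[C@H](C)O)C1=CC(=O)c2c(O)ccc(O)c2C1=O`, which gives 24500 nM; the difference a 1.2-fold lower number from compound 1 to compound 3 (0.08 log units; within the scatter) lies within the scatter, so the two cannot be ranked against each other. Furthest away is compound 2 `CCCCC(O)CC(=O)O[C@H](CC=C(C)C)C1=CC(=O)c2c(O)ccc(O)c2C1=O`, with 45300 nM; the step of a 2.2-fold lower number from compound 2 to compound 3 (0.34 log units; beyond the scatter) is modest but beyond the scatter. The third measured step, a 1.8-fold higher number from compound 1 to compound 2 (0.27 log units; within the scatter), is also within the scatter.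

Compound 4 `CC(C)=CC[C@@H](OC(=O)C1CCCO1)C1=CC(=O)c2c(O)ccc(O)c2C1=O` differs from compound 3 in the acyl part of the ester: oxolan-2-yl in place of 2-hydroxy-2-methylbutyl on a carbonyl carbon. The measured steps that bear on this change are all alterations of the same part of the molecule, and none moved the number by much: the ether of compound 1 and the two hydroxy esters of compounds 2 and 3 all lie within a narrow band. Replacing the 2-hydroxy-2-methylbutyl group by oxolan-2-yl is therefore expected to give a step of about a 1.3-fold higher number from compound 3 to compound 4 (0.10 log units; within the scatter), that is, no change beyond the scatter in either direction. Compound 4 is estimated at 26000 nM, with a plausible range from 11000 nM to 60000 nM.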

Compound 4, half-maximal inhibitory concentration: 10500 nM
Compound 4: middle estimate off by 2.5-fold (0.39 log units), on the high side; measured number outside the range, below it.
By their numbers in this assay, from the lowest: compounds 4, 3, 1 and 2 (each within the scatter of the next, the first and the last beyond it).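

Placing oxolan-2-yl on the carbonyl carbon brings the first ring into this acyl position, and the group that enters has no hydrogen-bond donor, yet the position still accepts it in this assay. Unlike the earlier steps among the open-chain groups, this change separates compound 4 from both other neighbours, with a 4.3-fold lower number from compound 2 to compound 4 (0.63 log units; beyond the scatter) and a 2.3-fold lower number from compound 1 to compound 4 (0.37 log units; beyond the scatter), each modest but beyond the scatter. Against the closest comparison, however, the result is a 2.0-fold lower number from compound 3 to compound 4 (0.29 log units; within the scatter), which lies within the scatter, so compound 4 cannot be ranked against compound 3, and the ring with no donor cannot be said to differ from 2-hydroxy-2-methylbutyl, which has one donor and a defined stereocentre.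

The compounds shown leave open whether the ring or the absence of the hydroxy group separates compound 4 from compound 2, a question that an open-chain ether such as methoxymethyl or a ring amine such as pyrrolidin-2-yl on the same carbonyl carbon could help to answer. No measurement offered here explains any of these steps.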